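The source may hold more compounds than are shown below. What is called first, only, known or untested is meant among the compounds shown, and "the series" means these compounds.

Of the compounds shown here, three sharing one core have been measured in an ADME assay on MT4 cells (Homo sapiens) for cytotoxicity, read by MTT assay, with a stated time of 96 h; a lower number here means that less compound is tolerated, a higher number that more compound is tolerated. Compound 1 `CCN(CC)CC(=O)Nc1ccc(-c2nc3cc(C(F)(F)F)ccc3n2C)cc1` gives 9000 nM. Compound 3 `CCN(CC)CC(=O)Nc1ccc(-c2nc3cc(C(F)(F)F)ccc3[nH]2)cc1` gives 8000 nM, and compound 2 `COc1cc(-c2nc3cc(C(F)(F)F)ccc3[nH]2)cc(OC)c1OC` gives 4000 nM. On these numbers compound 1 sits at the top end: compound 3 cannot be told apart from it, since the step of a 1.1-fold lower number from compound 1 to compound 3 (0.05 log units; within the scatter) lies within the scatter, whereas compound 2 shows a clearly lower number, so that compound 1 and compound 2 are separated beyond the scatter.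

The next compound, compound 4 `Cn1c(-c2ccc(NC(=O)CN3CCCC3)cc2)nc2cc(C(F)(F)F)ccc21`, is reached from compound 1 by a single change at the chain that carries the amide: pyrrolidin-1-yl in place of diethylamino on a saturated chain carbon bound to a carbonyl carbon. Among the compounds with values here, the one measured step, a 1.1-fold lower number from compound 1 to compound 3 (0.05 log units; within the scatter), concerns the aromatic nitrogen of the core and not this chain, so it says nothing direct about the new change; the two values of compound 1 and compound 2 differ at another place again. Within the data shown here, with no measured step bearing on the exchange of diethylamino for pyrrolidin-1-yl, and the two groups counted alike in atoms and in hydrogen-bond acceptors, the expectation is a step of no size beyond the scatter, no change at the digits printed from compound 1 to compound 4 (within the scatter). Compound 4 is therefore estimated at 9000 nM, with a range from 4500 nM to 18000 nM.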

Compound 4, half-maximal cytotoxic concentration: 16000 nM
Beside the measured number, compound 4's estimate is 1.8-fold (0.25 log units) below it; the range from low to high includes it.
By their numbers in this assay, from the lowest: compounds 2, 3, 1 and 4 (each within the scatter of the next, the first and the last beyond it).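

Within the data shown here, the exchange of diethylamino for pyrrolidin-1-yl, on a saturated chain carbon bound to a carbonyl carbon, gives the first measured step at this chain, and in this assay it is a 1.8-fold higher number from compound 1 to compound 4 (0.25 log units; within the scatter). The earlier compounds shown here showed only what happens at the aromatic nitrogen of the shared core, so this is new: tying the open amine into a five-membered ring, with the heavy-atom count and the hydrogen-bond counts left as they were, produces no difference that can be told apart from the ordinary spread of repeated measurements for this one pair. Nothing measured here offers any explanation for the size of this step, and a single pair within the scatter gives little that would call for one.

As far as these compounds go, how other groups at this place would read in this assay remains open, for example the six-membered piperidin-1-yl, the oxygen-containing morpholin-4-yl, or a longer chain carrying the amine. Also open, from the compounds shown here alone, is whether pyrrolidin-1-yl gives the same picture when the aromatic nitrogen of the core carries hydrogen, as it does in compound 3, rather than methyl.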